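The compounds below may be only part of what the source reports. "The series", "measured", "known", "first", "only" and "open" are said of these compounds alone.

Compound 1 `O=C(Nc1ccc(Cl)c(-c2nnc3c(Cl)cccn23)c1)c1ccc(F)cc1Cl`: in a functional assay on U-251 cells (Homo sapiens) for antiproliferative activity, read by MTT assay, with a stated time of 72 h (a higher number here means a weaker inhibitor, a lower number a stronger inhibitor), compound 1 gives > 100000 nM, a limit of the assay.
Compound 2 `O=C(Nc1ccc(Cl)c(-c2nnc3c(Cl)cccn23)c1)c1cccc(Cl)c1`: compound 2 gives 43100 nM.
Compound 3 `Cc1cc(Cl)ccc1C(=O)Nc1ccc(Cl)c(-c2nnc3c(Cl)cccn23)c1`: compound 3 gives > 100000 nM, also a limit of the assay.

Compound 1 therefore stands only at a limit, not at a number; this is the limit of > 100000 nM in this assay, at which 2 of the 3 values shown sit. The step to compound 4 `O=C(Nc1ccc(Cl)c(-c2nnc3c(Cl)cccn23)c1)c1ccon1` is 1,2-oxazol-3-yl in place of 2-chloro-4-fluorophenyl on a carbonyl carbon. The measured steps all swap one substituted phenyl ring for another on the carbonyl carbon: an at least 2.3-fold lower number from compound 1 to compound 2 (0.36 log units; beyond the scatter), an at least 2.3-fold higher number from compound 2 to compound 3 (0.36 log units; beyond the scatter), and a step that the two limits leave unreadable from compound 1 to compound 3. None of them replaces the phenyl ring with a five-membered ring, so they give no direction for this change. With compound 1 at the limit, compound 4 is expected to remain a weak inhibitor, with a step of an at least 1.1-fold lower number from compound 1 to compound 4 (0.04 log units; that floor lies within the scatter) that is not expected to go beyond the scatter. The value for compound 4 is estimated at 90000 nM, within 25000 nM to 300000 nM.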

Compound 4, half-maximal inhibitory concentration: > 100000 nM
Compound 4: no number, only a limit (the forecaster's own chance of this, stated with the estimate: 60%); at least 1.1-fold (0.04 log units) between middle value and limit.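

In this assay compound 4 gives > 100000 nM, a limit and not a number, so a five-membered ring on the carbonyl carbon gives no measurable value here, just as two of the substituted phenyl rings gave none. Compared with compound 2, the only compound with a number, the change gives an at least 2.3-fold higher number from compound 2 to compound 4 (0.36 log units; beyond the scatter). The steps to compound 4 from compound 1 and compound 3 cannot be read, and the values now crowd at one end: the limit of > 100000 nM in this assay, at which 3 of the 4 values shown sit.

On these data alone, whether a pyridine ring in this place, or an amine or a carboxylic acid on the ring, would give a measurable value stays open. As far as these compounds go, how far apart the compounds at the limit truly lie also stays open.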